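Swapping 3-nitrophenyl for 2,4-difluorophenyl on the shared core

The compounds below may be only part of what the source reports. "The series", "measured", "known", "first", "only" and "open" are said of these compounds alone.

Measured in a functional assay on A549 cells (Homo sapiens) for antiproliferative activity, read by MTT assay; a lower number here means a stronger inhibitor, a higher number a weaker inhibitor:
- Compound 1 `Cc1ccc(/C=N/Nc2ncc3c(n2)n(C2CCCC2)c(=O)c(=O)n3C)cc1C`: 30200 nM
- Compound 2 `Cn1c(=O)c(=O)n(C2CCCC2)c2nc(N/N=C/c3ccc(F)cc3Br)ncc21`: 6590 nM
- Compound 3 `Cn1c(=O)c(=O)n(C2CCCC2)c2nc(N/N=C/c3cccc([N+](=O)[O-])c3)ncc21`: 12300 nM

Compound 3 cannot be separated from compound 2, as the gap lies within the scatter: a 1.9-fold higher number from compound 2 to compound 3 (0.27 log units; within the scatter). It stands clearly apart from compound 1: a 2.5-fold lower number from compound 1 to compound 3 (0.39 log units; beyond the scatter). Compound 4 `Cn1c(=O)c(=O)n(C2CCCC2)c2nc(N/N=C/c3ccc(F)cc3F)ncc21` is not yet measured. It carries 2,4-difluorophenyl in place of 3-nitrophenyl on a carbon with a double bond to nitrogen. The nearest guide is compound 2, with 2-bromo-4-fluorophenyl, which gave a 4.6-fold lower number from compound 1 to compound 2 (0.66 log units; beyond the scatter). Since that group and 3-nitrophenyl gave values within the scatter of each other, no step beyond the scatter is expected in this assay, at most a slight drop. The expected change is a 1.4-fold lower number from compound 3 to compound 4 (0.14 log units; within the scatter). For compound 4 the estimated value is 9000 nM, with an expected range of 3800 nM to 21000 nM.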

Compound 4, half-maximal inhibitory concentration: 18300 nM
Compound 4: middle estimate off by 2.0-fold (0.31 log units), on the low side, within the range that was stated.
By their numbers in this assay, from the lowest: compounds 2, 3, 4 and 1 (each within the scatter of the next, the first and the last beyond it).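

With a 1.5-fold higher number from compound 3 to compound 4 (0.17 log units; within the scatter) and with a 1.7-fold lower number from compound 1 to compound 4 (0.22 log units; within the scatter) in this assay, 2,4-difluorophenyl cannot be separated from either 3-nitrophenyl or 3,4-dimethylphenyl on this carbon. Only a 2.8-fold higher number from compound 2 to compound 4 (0.44 log units; beyond the scatter) lies beyond the scatter, so exchanging bromo for fluoro on an aromatic carbon, while the rest of the molecule stays the same, is enough to move the number. Nothing measured here explains that step. Still open, from the compounds shown here alone, is how this assay would respond to an amine or a carboxylic acid on the phenyl ring, and whether chloro would fall with bromo or with fluoro.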